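A few compounds are considered here, and "the series" means these few. Any claim that something is new, unique, unknown or untested is made for them only; others in the source may bear on it.

Measured compounds in a functional assay on SF-539 cells (Homo sapiens) for antiproliferative activity, with a stated time of 48 h; on this read-out lower numbers stand for higher toxicity in this test and higher numbers for lower toxicity in this test:

- compound 1, `Cc1cc(O)c(C2=NN(c3ccc(S(N)(=O)=O)cc3)C(c3ccccc3O)C2)cc1Cl`, gives 5690 nM
- compound 2, `Cc1cc(O)c(C2=NN(c3ccc(S(N)(=O)=O)cc3)C(/C=C/c3ccccc3)C2)cc1Cl`, gives 37500 nM

Compound 2 stands at the highest of the two numbers shown, and the only measured step leads to it: a 6.6-fold higher number from compound 1 to compound 2 (0.82 log units; beyond the scatter). Compound 3, `COc1ccc(C2CC(c3cc(Cl)c(C)cc3O)=NN2c2ccc(S(N)(=O)=O)cc2)c(OC)c1OC`, differs from compound 2 by 2,3,4-trimethoxyphenyl in place of 2-phenylethenyl on a saturated ring carbon. Within the data shown here, only that one step bears on this change. In it, an aromatic ring on that saturated ring carbon gave the lower number and the 2-phenylethenyl group the higher one. Compound 3 brings an aromatic ring back to the same position, though not the 2-hydroxyphenyl of compound 1, so the number in this assay is expected to fall beyond the scatter, undoing much of that earlier step; the expected step is a 4.2-fold lower number from compound 2 to compound 3 (0.62 log units; beyond the scatter). Compound 3 is therefore estimated at 9000 nM, with a range from 2000 nM to 40000 nM.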

Compound 3, concentration lethal to 50% of the cells: 6420 nM
Compound 3: the middle estimate sits 1.4-fold (0.15 log units) above what was measured; the measured number falls inside the stated range.
By their numbers in this assay, from the lowest: compounds 1 and 3 (each within the scatter of the next); then compound 2.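

Going from 2-phenylethenyl to 2,3,4-trimethoxyphenyl on this saturated ring carbon gives a 5.8-fold lower number from compound 2 to compound 3 (0.77 log units; beyond the scatter) in this assay and so brings the number back to the level of the 2-hydroxyphenyl group. The comparison of the two aromatic groups gives a 1.1-fold higher number from compound 1 to compound 3 (0.05 log units; within the scatter) in this assay, so the hydroxyl of 2-hydroxyphenyl is not required at this position, and three methoxy groups on the ring serve equally well in this test. Among the three compounds, only 2-phenylethenyl stands apart, and no measurement at hand bears on the reason for this.

The compounds shown leave open whether the number depends on an aromatic ring sitting directly on this carbon or on the double bond of 2-phenylethenyl. An unsubstituted phenyl, a benzyl or a cyclohexyl group here would help separate these two readings.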